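This account rests on a few compounds, and the source may have more. Where it says the series, first, only, none or still open, it means among the compounds named here.

Of the compounds shown here, two have been measured so far in a functional assay on HL-60 cells (Homo sapiens) for inhibition, read by MTT assay, with a stated time of 72 h (a lower number here means a stronger inhibitor, a higher number a weaker inhibitor), on the way to compound 3. Compound 1 `CC1(C)/C=C\C(=O)[C@@]2(C)O[C@H]2CCC2=C[C@@H]1OC2=O` gives 5400 nM in this test. Compound 2 `C[C@@H]1C(=O)/C=C\C(C)(C)[C@@H]2C=C(CC[C@@H]1O)C(=O)O2` reads > 10000 nM in this assay and that reading is a limit, not a number. Compound 3 `CCO[C@H]1CCC2=C[C@H](OC2=O)C(C)(C)/C=C\C(=O)[C@H]1C` has yet to be measured. The change from compound 2 is ethyl in place of hydrogen on an oxygen on a saturated carbon and in words it is ethyl in place of hydrogen on an oxygen on a saturated carbon, hydroxy to ethoxy. Going by the values given here, no measured pair shows this change, so compound 2 is the only close reference and no step beyond the scatter is expected in this assay in either direction. The estimated step that the limit leaves unreadable from compound 2 to compound 3 is accordingly small. For compound 3 the expected value is 12000 nM within an estimated range from 5000 nM to 30000 nM in this test.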

Compound 3, half-maximal inhibitory concentration: > 10000 nM
Compound 3 was reported as a limit (the forecaster's own chance of this, stated with the estimate: 60%); the middle value does not contradict the limit.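

The step from compound 2 to compound 3 cannot be read, because both compounds are reported only as limits: the limit of > 10000 nM in this assay, at which 2 of the 3 values shown sit. The compounds shown leave open whether hydroxy to ethoxy, ethyl in place of hydrogen on that oxygen, alters inhibition at all.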